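The source may hold more compounds than are shown below. What is called first, only, known or untested is meant among the compounds shown, and "the series" means these compounds.

Measured compounds:
compound 1 `CCCCc1ccc2c(c1)C(=O)C(=O)N2`: > 10000 nM
compound 2 `COc1ccc(-c2ccc3c(c2)C(=O)C(=O)N3Cc2ccccc2OC)cc1`: 130 nM
compound 3 `COc1ccc(CN2C(=O)C(=O)c3cc(-c4ccc(C(C)(C)C)cc4)ccc32)cc1`: 4580 nM

In a functional assay on HepG2 cells (Homo sapiens) for antiproliferative activity, read by MTT assay, with a stated time of 48 h (a higher number here means a weaker inhibitor, a lower number a stronger inhibitor), compound 1 gives > 10000 nM, which is a limit of the assay rather than a number (the limit of > 10000 nM in this assay, at which 1 of the 3 values shown sits). Compound 2 gives 130 nM in this assay. Compound 3 gives 4580 nM, the higher of the two numbers, with compound 2 lower by a gap beyond the scatter. Compound 4 `COc1ccc(CN2C(=O)C(=O)c3cc(-c4ccc(C(F)(F)F)cc4)ccc32)cc1` is not yet measured; it differs from compound 3 by trifluoromethyl in place of tert-butyl on an aromatic carbon. For the measured compounds named here, no pair of measured compounds shows this exchange. A modest move toward a lower number is expected, a 2.3-fold lower number from compound 3 to compound 4 (0.36 log units; beyond the scatter) in this assay, not clearly beyond the scatter. Compound 4 is estimated at 2000 nM, between 500 nM and 8000 nM.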

Compound 4, half-maximal inhibitory concentration: 820 nM
The estimate for compound 4 lay 2.4-fold (0.39 log units) above the measured number; the range from low to high includes it.
By their numbers in this assay, from the lowest: compound 2; then compound 4; then compound 3. At a limit, above all of these: compound 1.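

In this assay, for the compounds shown here, the position para to a large group proves sensitive to its substituent: 4-(trifluoromethyl)phenyl in place of 4-(tert-butyl)phenyl gives a 5.6-fold lower number from compound 3 to compound 4 (0.75 log units; beyond the scatter) and supplies the first one-place comparison. The earlier compounds shown here offered no such pair, so this position could not be read on its own until now. No measurement shown accounts for this step.

Still open, from the compounds shown here alone, is how an amine, a carboxylic acid or a longer chain at this position would read in this assay. Going by these compounds, whether the same exchange gives a similar step with other groups elsewhere on the shared core also remains unknown.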